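Replacing Hydroxy with Dimethylamino in Compound 3

A few compounds are considered here, and "the series" means these few. Any claim that something is new, unique, unknown or untested is made for them only; others in the source may bear on it.

In a functional assay on A549 cells (Homo sapiens) for antiproliferative activity, read by MTT assay, with a stated time of 48 h (on this read-out lower numbers stand for stronger inhibition and higher numbers for weaker inhibition), compound 1 (`COc1ccc(C(=O)c2ccc(OC)c3c2C=CC(C)(C)O3)c(NC(=O)CBr)c1`) gives 2460 nM while compound 2 (`COc1ccc(C(=O)c2cc(OC)c(OC)c(OC)c2)c(NC(=O)CO)c1`) gives 70 nM and compound 3 (`C=C(c1ccc(OC)cc1NC(=O)CO)c1ccc(OC)c2c1OC(C)(C)C=C2`) gives 40 nM in the same units. Compound 3 thus lies far under compound 1 but within the usual scatter of compound 2. Compound 4 (`C=C(c1ccc(OC)cc1NC(=O)CN(C)C)c1ccc(OC)c2c1OC(C)(C)C=C2`) puts dimethylamino in place of hydroxy on a saturated chain carbon bound to a carbonyl carbon. For the measured compounds named here, no measured pair shows this change, so any expectation is loose. Compound 2 and compound 3 both carry the hydroxy, and replacing it may cost some activity. In this assay the expectation is a modest estimated step of a 2.5-fold higher number from compound 3 to compound 4 (0.40 log units; beyond the scatter) toward weaker inhibition. Compound 4 is expected at 100 nM (estimated range 30 nM to 400 nM).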

Compound 4, half-maximal inhibitory concentration: 270 nM
The estimate for compound 4 lay 2.7-fold (0.43 log units) below the measured number; the range from low to high includes it.
By their numbers in this assay, from the lowest: compounds 3 and 2 (each within the scatter of the next); then compound 4; then compound 1.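

At this saturated chain carbon bound to a carbonyl carbon, the group clearly counts: in this assay, dimethylamino in place of hydroxy gives a 6.8-fold higher number from compound 3 to compound 4 (0.83 log units; beyond the scatter), toward weaker inhibition. The change removes a hydrogen-bond donor and adds heavy atoms, and this single pair cannot separate those two differences. Nothing measured here explains the loss.

As far as these compounds go, whether a smaller amine such as methylamino, or a longer chain ending in hydroxy, would hold the activity of compound 3 remains open. So does whether the same change would cost as much on the core of compound 2.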